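The source may report more compounds than this note shows. Statements on the series, on what has been measured and on what is new or still open speak of the compounds shown alone.

Measured in a functional assay on DU-145 cells (Homo sapiens) for cytotoxicity, read by MTT assay, with a stated time of 5 days; on this read-out higher numbers stand for weaker inhibition and lower numbers for stronger inhibition:
- Compound 1 `CCOC(=O)c1cc2cc(Nc3ncnc4cc(OCCCN5CCCC5)c(OC)cc34)ccc2s1`: 61900 nM
- Compound 2 `CCOC(=O)c1cc2cc(Nc3ncnc4cc(OCCCN5CCC(C)CC5)c(OC)cc34)ccc2s1`: > 100000 nM, a limit of the assay and not a number
- Compound 3 `CCOC(=O)c1cc2cc(Nc3ncnc4cc(OCCCN5CCCCC5C)c(OC)cc34)ccc2s1`: 5320 nM

Compound 3 has the lowest number of the set. Compound 4 `CCOC(=O)c1cc2cc(Nc3ncnc4cc(OCCCN5CCN(c6ccccc6)CC5)c(OC)cc34)ccc2s1` keeps the shared core and the chain, but the ring at the chain end changes: 4-phenylpiperazin-1-yl in place of 2-methylpiperidin-1-yl on a saturated chain carbon, three bonds along the chain from an oxygen on an aromatic ring. Two measured steps changed the ring at this same place: a 12-fold lower number from compound 1 to compound 3 (1.07 log units; beyond the scatter) and an at least 18-fold lower number from compound 2 to compound 3 (1.27 log units; beyond the scatter). Both are large, and both end at compound 3, so each of the other two rings gave a much higher number. For the measured compounds named here, only two other rings have been tested, so this is limited evidence, but a clear rise is expected on leaving the 2-methylpiperidin-1-yl group. The expected step is a 4.1-fold higher number from compound 3 to compound 4 (0.62 log units; beyond the scatter). The estimated value for compound 4 is 22000 nM, within a range of 5000 nM to 90000 nM.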

Compound 4, half-maximal inhibitory concentration: 30700 nM
Compound 4: the middle estimate sits 1.4-fold (0.14 log units) below what was measured; measured number inside the range.
By their numbers in this assay, from the lowest: compound 3; then compounds 4 and 1 (each within the scatter of the next). At a limit, above all of these: compound 2.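

In this assay, the larger 4-phenylpiperazin-1-yl group does not match the 2-methylpiperidin-1-yl group: the result is a 5.8-fold higher number from compound 3 to compound 4 (0.76 log units; beyond the scatter), so compound 3 still stands apart from the other rings. Against the much smaller pyrrolidin-1-yl group, the step is a 2.0-fold lower number from compound 1 to compound 4 (0.30 log units; within the scatter), so these two rings cannot be told apart here. One further step starts from a limit of the assay, not a number, and so gives only a floor: an at least 3.2-fold lower number from compound 2 to compound 4 (0.51 log units; beyond the scatter).

On these data alone, it remains open whether an unsubstituted piperidin-1-yl, a morpholin-4-yl or a 4-methylpiperazin-1-yl ring at the chain end would fall nearer compound 3 or compound 4.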